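Amide substituent change from compound 1 to compound 3

The source may report more compounds than this note shows. Statements on the series, on what has been measured and on what is new or still open speak of the compounds shown alone.

Among the measured compounds shown here, compound 1 `CCn1c(C(=O)N[C@@H](C)CO)ccc1C(CC)(CC)c1ccc(OCS(=O)(=O)c2ccccc2)c(C)c1` gives the lowest of the two numbers so far: in a functional assay on MCF7 cells (Homo sapiens) for antiproliferative activity, read by MTT assay, with a stated time of 24 h (on this read-out higher numbers stand for weaker inhibition and lower numbers for stronger inhibition), compound 1 gives 10800 nM. Its nearest neighbour, compound 2 `CCn1c(C(=O)NC(C)(C)CO)ccc1C(CC)(CC)c1ccc(OCS(=O)(=O)c2ccccc2)c(C)c1`, gives 20700 nM, and a 1.9-fold higher number from compound 1 to compound 2 (0.28 log units; within the scatter). Compound 3 `CCn1c(C(=O)NCCC(=O)O)ccc1C(CC)(CC)c1ccc(OCS(=O)(=O)c2ccccc2)c(C)c1` differs from compound 1 as follows: 2-carboxyethyl in place of 1-(hydroxymethyl)ethyl on an amide-type nitrogen. For the measured compounds named here, no measured step covers this change; the only step at the same position stayed within the scatter, so no shift beyond the scatter is expected, and compound 3 is estimated to show a 1.4-fold higher number from compound 1 to compound 3 (0.14 log units; within the scatter). Compound 3 is therefore expected to give about 15000 nM, between 5000 nM and 45000 nM.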

Compound 3, half-maximal inhibitory concentration: > 50000 nM
Compound 3: a limit, no number; the forecaster's own chance of this, stated with the estimate: 20%; at least 3.3-fold (0.52 log units) between middle value and limit.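

At the amide-type nitrogen, the earlier step had stayed within the scatter, but in this assay, 2-carboxyethyl in place of 1-(hydroxymethyl)ethyl gives an at least 4.6-fold higher number from compound 1 to compound 3 (0.66 log units; beyond the scatter), and in place of 1-(hydroxymethyl)-1-methylethyl it gives an at least 2.4-fold higher number from compound 2 to compound 3 (0.38 log units; beyond the scatter). Among the compounds shown here, these are the first steps at this position that lie beyond the scatter, so the position does not accept every substituent equally. The value of compound 3 is a limit, not a number: the limit of > 50000 nM in this assay, at which 1 of the 3 values shown sits.

The compounds shown leave open whether the carboxylic acid itself or the chain carrying it accounts for this step. A methyl ester, a primary amide or a 3-hydroxypropyl chain at this nitrogen would separate the two.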